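Replacing the 2-chloro-4-fluorophenyl group of compound 2

A few compounds are considered here, and "the series" means these few. Any claim that something is new, unique, unknown or untested is made for them only; others in the source may bear on it.

In a functional assay on HCT-116 cells (Homo sapiens) for antiproliferative activity, read by MTT assay (a lower number here means a stronger inhibitor, a higher number a weaker inhibitor), compound 1 (`Cn1c(=O)c(=O)n(C2CCCC2)c2nc(N/N=C/c3ccccc3)ncc21`) gives > 100000 nM as a limit of the assay, not a number. Among the compounds with values here, compound 2 (`Cn1c(=O)c(=O)n(C2CCCC2)c2nc(N/N=C/c3ccc(F)cc3Cl)ncc21`) gives 13800 nM as the only actual number so far. Within the data shown here, the single measured step of an at least 7.2-fold lower number from compound 1 to compound 2 (0.86 log units; beyond the scatter) came with 2-chloro-4-fluorophenyl in place of phenyl on a carbon with a double bond to nitrogen. Compound 3 (`Cn1c(=O)c(=O)n(C2CCCC2)c2nc(N/N=C/c3cccc(O)c3)ncc21`) has 3-hydroxyphenyl in place of 2-chloro-4-fluorophenyl at that carbon (3-hydroxyphenyl in place of 2-chloro-4-fluorophenyl on a carbon with a double bond to nitrogen) and so gives up the chlorine and fluorine of compound 2. Among the measured compounds shown here, no measured step covers a hydroxyl group. For the measured compounds named here, with an at least 7.2-fold lower number from compound 1 to compound 2 (0.86 log units; beyond the scatter) as the only guide, part of that gain is expected to be lost in this assay, giving a higher number. The estimated step is a 2.5-fold higher number from compound 2 to compound 3 (0.40 log units; beyond the scatter) in that direction. For compound 3 the expected value is 35000 nM with an estimated range from 10000 nM to 100000 nM and a real chance of only a limit.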

Compound 3, half-maximal inhibitory concentration: 37200 nM
The estimate for compound 3 lay 1.1-fold (0.03 log units) below the measured number; the range from low to high includes it.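

In this assay, a change at the carbon with a double bond to nitrogen no longer rests on halogens alone: hydroxy in place of hydrogen on an aromatic carbon gives an at least 2.6-fold lower number from compound 1 to compound 3 (0.42 log units; beyond the scatter). The exchange of 2-chloro-4-fluorophenyl for 3-hydroxyphenyl gives a 2.7-fold higher number from compound 2 to compound 3 (0.43 log units; beyond the scatter), so the two substituted phenyl groups are now separated beyond the scatter, with the halogenated one holding the lower number. Compound 1 carries a limit and not a number, so the steps starting from it have an open size: the limit of > 100000 nM in this assay, at which 1 of the 3 values shown sits.

The compounds shown leave the separate contributions of chlorine and fluorine unresolved, and they do not tell the hydroxy group itself from its place on the ring. From the compounds shown here alone, how a methoxy group, an amine or a carboxylic acid on the phenyl would read also remains open.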